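The source may hold more compounds than are shown below. What is called first, only, known or untested is meant among the compounds shown, and "the series" means these compounds.

Measured so far in an ADME assay on microsomes from liver (Rattus norvegicus) for metabolic stability; on this read-out higher numbers stand for a longer-lived compound and lower numbers for a shorter-lived compound:
compound 1 `CC(C)C(Nc1nnc[nH]1)c1ccc(-c2ccc3cccc(F)c3c2)[nH]c1=O`, 1.29 h
compound 2 `CC(C)C(c1ncco1)c1ccc(-c2ccc3cccc(F)c3c2)[nH]c1=O`, 0.0983 h
compound 3 `CC(C)C(c1cnc(N)s1)c1ccc(-c2ccc3cccc(F)c3c2)[nH]c1=O`, 0.0983 h

Compound 1 stands highest of the three numbers. Compound 4 `CC(C)C(c1ccc(-c2ccc3cccc(F)c3c2)[nH]c1=O)N1CCNC1=O` is the step considered here: 2-oxoimidazolidin-1-yl in place of (4H-1,2,4-triazol-3-yl)amino on a saturated chain carbon bound to an aromatic carbon and a saturated chain carbon. Among the compounds with values here, two measured steps bear on it, as each also removes the (4H-1,2,4-triazol-3-yl)amino group of compound 1: a 13-fold lower number from compound 1 to compound 2 (1.12 log units; beyond the scatter) and a 13-fold lower number from compound 1 to compound 3 (1.12 log units; beyond the scatter). Both are large and downward, and compound 2 and compound 3 agree with each other: no change at the digits printed from compound 2 to compound 3 (within the scatter). The group entering compound 4 is one five-membered non-aromatic ring with 2 hetero atoms rather than an aromatic ring, and a drop smaller than those two steps is expected, a 3.7-fold lower number from compound 1 to compound 4 (0.57 log units; beyond the scatter). Compound 4 is therefore estimated at 0.35 h, with a range from 0.1 h to 1.3 h.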

Compound 4, half-life: 0.283 h
Beside the measured number, compound 4's estimate is 1.2-fold (0.09 log units) above it; low and high end bracket the measured number.
By their numbers in this assay, from the lowest: compounds 2 and 3 (each within the scatter of the next); then compound 4; then compound 1.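

In this assay this saturated chain carbon now shows a middle level, with a 4.6-fold lower number from compound 1 to compound 4 (0.66 log units; beyond the scatter) but also a 2.9-fold higher number from compound 3 to compound 4 (0.46 log units; beyond the scatter) and a 2.9-fold higher number from compound 2 to compound 4 (0.46 log units; beyond the scatter) for 2-oxoimidazolidin-1-yl. Replacing (4H-1,2,4-triazol-3-yl)amino therefore need not cost the full drop seen with the two aromatic rings, though this non-aromatic ring still stays short of compound 1. Nothing measured here explains this order.

As far as these compounds go, it remains open whether the non-aromatic ring or its carbonyl sets the level. From the compounds shown here alone, it is also open whether an open-chain urea or a plain amine on this carbon would match compound 1.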